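The source may hold more compounds than are shown below. What is called first, only, known or untested is meant among the compounds shown, and "the series" means these compounds.

Measured in a physicochemical assay for solubility, read by LC-MS, in phosphate buffer, with a stated time of 24 h, at pH 7.4; on this read-out lower numbers stand for lower solubility and higher numbers for higher solubility:
- compound 1 `CN(c1ncco1)c1cnc(NCc2c(F)ccc3c2CCO3)n2cnnc12`: 67000 nM
- compound 2 `Cc1nccn1-c1cnc(NCc2c(F)ccc3c2CCO3)c2cn[nH]c(=O)c12`: 7000 nM
- compound 3 `Cn1nccc1-c1cnc(NCc2c(F)ccc3c2CCO3)c2cn[nH]c(=O)c12`: 2000 nM

Compound 3 has the lowest number of the three, 2000 nM. The nearest is compound 2 at 7000 nM and the furthest is compound 1 at 67000 nM, both gaps beyond the scatter.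

The next change leads to compound 4 `O=C1CCCN1c1cnc(NCc2c(F)ccc3c2CCO3)c2cn[nH]c(=O)c12`: 2-oxopyrrolidin-1-yl in place of 1-methyl-1H-pyrazol-5-yl on an aromatic carbon. In short, 2-oxopyrrolidin-1-yl comes in place of 1-methyl-1H-pyrazol-5-yl on an aromatic carbon, so a five-membered non-aromatic ring replaces a five-membered aromatic ring.

Within the data shown here, one measured step bears on this, a 3.5-fold lower number from compound 2 to compound 3 (0.54 log units; beyond the scatter), a modest exchange of one ring group for another at the same place. Among the measured compounds shown here, no measured compound carries a non-aromatic ring there, so a step of similar modest size is expected. With compound 3 at 2000 nM, the lowest so far, a rise is the likelier direction, though only weakly supported.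

The expected change is a 2.5-fold higher number from compound 3 to compound 4 (0.40 log units; beyond the scatter). For compound 4 the estimated value is 5000 nM, with an expected range of 1500 nM to 18000 nM.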

Compound 4, solubility: < 2000 nM
Compound 4: no number, only a limit; the forecaster's own chance of this, stated with the estimate: 5%; middle value at least 2.5-fold (0.39 log units) away from the limit.
By their numbers in this assay, from the lowest: compound 3; then compound 2; then compound 1.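

In this assay compound 4 gives < 2000 nM, which is a limit and not a number: the limit of < 2000 nM in this assay, at which 1 of the 4 values shown sits. At this aromatic carbon, a five-membered non-aromatic ring now sits alongside the two aromatic rings, and 2-oxopyrrolidin-1-yl in place of 2-methyl-1H-imidazol-1-yl gives an at least 3.5-fold lower number from compound 2 to compound 4 (0.54 log units; beyond the scatter). 2-oxopyrrolidin-1-yl in place of 1-methyl-1H-pyrazol-5-yl gives a number no higher from compound 3 to compound 4 (the limit leaves the size open), showing only that 2-oxopyrrolidin-1-yl brings no rise over 1-methyl-1H-pyrazol-5-yl.

On these data alone, how far compound 4 lies under the limit stays open, and with it whether the non-aromatic ring differs from 1-methyl-1H-pyrazol-5-yl at all. Also open, as far as these compounds go, is whether an open-chain amine or a carboxylic acid on this aromatic carbon would bring the number back above the limit.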